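Compound 3 after the trifluoromethyl cyclobutyl step

A few compounds are considered here, and "the series" means these few. Any claim that something is new, unique, unknown or untested is made for them only; others in the source may bear on it.

Measured in an in vitro ADME assay on microsomes from liver (Homo sapiens) for metabolic stability, tested at 5 uM (a higher number here means that the compound lasts longer, a lower number that the compound disappears faster), so far
Compound 1 `CS(=O)(=O)Nc1ccc2c(c1)S(=O)(=O)N=C(c1c(O)c(-c3cccs3)nn(CC3CCC3)c1=O)N2` gives > 1 h as a limit
Compound 2 `CS(=O)(=O)Nc1ccc2c(c1)S(=O)(=O)N=C(c1c(O)c(-c3cccs3)nn(CC3(C(F)(F)F)CCC3)c1=O)N2` gives 1 h as a number

Compound 2 holds the only exact half-life, with 1 h as its value. Compound 1 stands at a limit (the limit of > 1 h in this assay, at which 1 of the 2 values shown sits). Compound 3 `CS(=O)(=O)Nc1ccc2c(c1)S(=O)(=O)N=C(c1c(O)c(-c3cccs3)nn(CCC3CCCCC3)c1=O)N2` has not yet been measured, and its structure departs from compound 2 as follows: cyclohexylmethyl in place of 1-(trifluoromethyl)cyclobutyl on a saturated chain carbon bound to an aromatic nitrogen with cyclohexylmethyl in place of 1-(trifluoromethyl)cyclobutyl on a saturated chain carbon bound to an aromatic nitrogen. Among the compounds with values here, one measured step bears on this change (a number no higher from compound 1 to compound 2 (the limit leaves the size open)). As far as these compounds go, its size stays open, and it gives no direction for this exchange. The expectation therefore rests on compound 2 at 1 h alone, and no shift beyond the usual scatter is expected in this assay for now. The estimated step is a 1.3-fold lower number from compound 2 to compound 3 (0.10 log units; within the scatter) and no more. Compound 3 is estimated at 0.8 h (expected range 0.35 h to 1.5 h).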

Compound 3, half-life: > 1 h
Compound 3: no number, only a limit; the forecaster's own chance of this, stated with the estimate: 30%; middle value at least 1.2-fold (0.09 log units) from the limit.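

In this assay, cyclohexylmethyl in place of 1-(trifluoromethyl)cyclobutyl on a saturated chain carbon bound to an aromatic nitrogen gives a number no lower from compound 2 to compound 3 (the limit leaves the size open). This shows that the position accepts a six-membered carbon ring without trifluoromethyl and with no drop in half-life from compound 2, although the size of this step cannot be read, and neither can the step between compound 1 and compound 3. Compound 3, like compound 1, gives a limit rather than a number, so the two cannot be ordered: the limit of > 1 h in this assay, at which 2 of the 3 values shown sit.

The compounds shown leave open how far compound 1 and compound 3 lie past that limit. They also leave open what an amine, a carboxylic acid or a hydroxyl on this chain would do to the half-life.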